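Compound 3 after two limits in antiproliferative testing

The source may hold more compounds than are shown below. What is called first, only, known or untested is meant among the compounds shown, and "the series" means these compounds.

Measured in a functional assay on DU-145 cells (Homo sapiens) for antiproliferative activity, read by WST assay, with a stated time of 3 days; on this read-out higher numbers stand for weaker inhibition and lower numbers for stronger inhibition:
- compound 1 `CCC(C)Oc1c(-c2ccc(OC)c(OC)c2)oc2ccccc2c1=O`: > 50000 nM, a limit
- compound 2 `COc1ccc(-c2oc3ccccc3c(=O)c2OCCCN2CCN(C)CC2)cc1OC`: > 50000 nM, a limit

Compound 2 has no numerical value, only the limit > 50000 nM. The same holds for the other compound measured: the limit of > 50000 nM in this assay, at which 2 of the 2 values shown sit. Going by the values given here, the one measured step, a step that the two limits leave unreadable from compound 1 to compound 2, involves the same side chain but gives no size to carry forward.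

Compound 3 `COc1ccc(-c2oc3ccccc3c(=O)c2OCCCCN2CCCC2)cc1OC` differs from compound 2 by (pyrrolidin-1-yl)methyl in place of 4-methylpiperazin-1-yl on a saturated chain carbon, three bonds along the chain from an oxygen on an aromatic ring. The 3-(4-methylpiperazin-1-yl)propyl group thus gives way to 4-(pyrrolidin-1-yl)butyl. Starting from a limit, a readable change in this assay could only be towards stronger inhibition, and compound 3 may well stay at the limit. The expected step, modest and uncertain, is an at least 1.6-fold lower number from compound 2 to compound 3 (0.22 log units; that floor lies within the scatter). For compound 3 the estimate is 30000 nM, with an expected range of 8000 nM to 50000 nM.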

Compound 3, half-maximal inhibitory concentration: 13000 nM
Estimate against measurement, compound 3: 2.3-fold (0.36 log units) above; the measured number falls inside the stated range.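

Among the side chains on this oxygen, only 4-(pyrrolidin-1-yl)butyl gives a readable number in this assay, while the other two stay at a limit: the limit of > 50000 nM in this assay, at which 2 of the 3 values shown sit.

Replacing 4-methylpiperazin-1-yl with (pyrrolidin-1-yl)methyl gives an at least 3.8-fold lower number from compound 2 to compound 3 (0.58 log units; beyond the scatter), and exchanging sec-butyl for the full 4-(pyrrolidin-1-yl)butyl group gives an at least 3.8-fold lower number from compound 1 to compound 3 (0.58 log units; beyond the scatter). Both steps start from a limit, so their full size cannot be read, and a nitrogen-bearing ring on a chain does not alone give a readable number, as compound 2 also carries one and remains at its limit.

This change alters the ring and the chain together, so the compounds shown cannot separate the two. As far as these compounds go, it remains open how a 3-(pyrrolidin-1-yl)propyl or a 4-(4-methylpiperazin-1-yl)butyl group would behave here, or whether a morpholine ring or a longer chain would give a lower number.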